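The compounds below may be only part of what the source reports. "The series", "measured", "known", "first", "only" and "open" are said of these compounds alone.

Three compounds have been measured in a functional assay on HepG2 cells (Homo sapiens) for cytotoxicity, with a stated time of 24 h; on this read-out higher numbers stand for weaker inhibition and lower numbers for stronger inhibition:

compound 1, `COc1cc(Cl)ccc1C(=O)Nc1cc(Cl)ccc1O`, gives 87000 nM
compound 2, `COc1cc(Cl)ccc1C(=O)Nc1cc(Br)ccc1O`, gives 5630 nM
compound 3, `COc1ccc(Cl)cc1C(=O)Nc1ccc(Cl)cc1O`, gives 51300 nM

Compound 4, `COc1ccc(Cl)cc1C(=O)Nc1ccc(Br)cc1O`, has not yet been measured in this assay.

Compounds 1 and 3 are built from the same atoms joined differently; the difference between the two cores is not broken down here. Their values in this assay lie within the usual scatter of each other, so no order between them can be read from these numbers. Compound 2 stands well apart from both.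

The change from compound 1 to compound 2 is bromo in place of chloro on an aromatic carbon, and it gave a 15-fold lower number from compound 1 to compound 2 (1.19 log units; beyond the scatter). The change from compound 3 to compound 4 is bromo in place of chloro on an aromatic carbon. This is the same kind of change, but the place is not the same word for word: in compound 1 the carbon carrying the halogen is meta to a large group and para to a hydroxy group, whereas in compound 3 it is meta to a hydroxy group and para to a large group. Among the compounds with values here, the only guide is a single earlier example, the step of a 15-fold lower number from compound 1 to compound 2 (1.19 log units; beyond the scatter), and since the surroundings of the place differ, the expected step from compound 3 to compound 4 is held more loosely and a little smaller, as a 6.4-fold lower number from compound 3 to compound 4 (0.81 log units; beyond the scatter). Compound 4 is therefore estimated to give 8000 nM in this assay, with a range from 2000 nM to 30000 nM.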

Compound 4, half-maximal inhibitory concentration: 7980 nM
Estimate against measurement, compound 4: 1.0-fold (0.00 log units) above; the measured number falls inside the stated range.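

In this assay, bromo in place of chloro on an aromatic carbon again goes with a lower number, with a 6.4-fold lower number from compound 3 to compound 4 (0.81 log units; beyond the scatter), so the change points the same way on both cores shown. The two steps cannot be told apart in size: the same change on two cores in this assay, a 15-fold lower number (1.19 log units; beyond the scatter) from compound 1 to compound 2 and a 6.4-fold lower number (0.81 log units; beyond the scatter) from compound 3 to compound 4, 2.4-fold (0.38 log units) apart, within the scatter of two such steps. This supports treating the change as one that carries over between these two cores, despite the different surroundings of the halogen, but two pairs are a narrow basis: they say nothing about how the change would behave on a core that differs further, and they do not show what the bromo group does in the cells to give the lower number.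

The compounds shown hold only chloro and bromo at this place, so it remains open whether iodo, fluoro or a nitrile there would extend the same trend or break it. Going by these compounds, it also remains open whether the step would persist with an amine in place of the hydroxy group, or with a longer chain such as ethoxy in place of the methoxy group, and whether it would appear in any read-out other than this one.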